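Taking the 4-methoxyphenyl off compound 2

The source may report more compounds than this note shows. Statements on the series, on what has been measured and on what is new or still open speak of the compounds shown alone.

In a physicochemical assay (on this read-out higher numbers stand for weaker inhibition and lower numbers for stronger inhibition), compound 1 (`CN(C)c1ccc(/C=C/C(=O)/C(CNc2cccc(C(F)(F)F)c2)=C(O)/C=C/c2ccc(N(C)C)cc2)cc1`) gives 74.6 ug/mL and compound 2 (`COc1ccc(-n2nc(/C=C/c3ccc(N(C)C)cc3)cc2/C=C/c2ccc(N(C)C)cc2)cc1`) gives 79.6 ug/mL and so the two stand level within the usual scatter. Compound 3 (`CN(C)c1ccc(/C=C/c2cc(/C=C/c3ccc(N(C)C)cc3)[nH]n2)cc1`) carries hydrogen in place of 4-methoxyphenyl on an aromatic nitrogen. Within the data shown here, no measured pair shows this kind of change, so the expectation is loose. A modest move toward stronger inhibition is expected, an estimated 1.3-fold lower number from compound 2 to compound 3 (0.12 log units; within the scatter) with wide uncertainty. For compound 3 the estimated value in this assay is 60 ug/mL (expected range 25 ug/mL to 150 ug/mL).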

Compound 3, half-maximal inhibitory concentration: 50.8 ug/mL
Beside the measured number, compound 3's estimate is 1.2-fold (0.07 log units) above it; measured number inside the range.
By their numbers in this assay, from the lowest: compounds 3, 1 and 2 (each within the scatter of the next).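

In this assay, taking the 4-methoxyphenyl off the aromatic nitrogen gives a 1.6-fold lower number from compound 2 to compound 3 (0.20 log units; within the scatter). This position can therefore lose that whole group, aromatic ring included, and leave the read-out level, so a bare ring nitrogen and one bearing 4-methoxyphenyl cannot be told apart here. Nothing measured on these compounds explains this outcome.

From the compounds shown here alone, what remains open is whether a small group on this nitrogen, such as methyl, would also read level. The same question stands for a longer chain ending in an amine or a carboxylic acid.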